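The source may hold more compounds than are shown below. What is called first, only, known or untested is meant among the compounds shown, and "the series" means these compounds.

Of the compounds shown here, three built on one shared core have been tested in a functional assay on the whole organism (strain albino) for inhibition, with Rattus norvegicus as the target, read by paw edema, with stated times of 1 h and 3 h, at a dose of 100 mg/kg by the oral route; a higher number here means a stronger effect of the compound at the dose given, a lower number a weaker effect. Compound 1 `N#Cc1c(-c2ccc(Cl)cc2)nc(SCC(=O)Nn2c(COc3ccc(Cl)cc3Cl)nc3ccccc3c2=O)[nH]c1=O` gives 64.9% in this assay. Compound 2 `N#Cc1c(-c2ccccc2)nc(SCC(=O)Nn2c(COc3ccc(Cl)cc3Cl)nc3ccccc3c2=O)n(Cc2ccccc2)c1=O` gives 79%. Compound 3 `Cn1c(SCC(=O)Nn2c(COc3ccc(Cl)cc3Cl)nc3ccccc3c2=O)nc(-c2ccc(Cl)cc2)c(C#N)c1=O` gives 73.7%, which places compound 3 second highest of the three, though its gaps to compound 2 and to compound 1 both lie within the scatter, so no ranking among the three can be claimed.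

Going by the values given here, the only measured step that changes a single place is a number 8.8 percentage points higher from compound 1 to compound 3 (within the scatter), a shift that stays within the scatter.

Compound 4 `N#Cc1c(-c2ccc(Cl)cc2)nc(SCC(=O)Nn2c(COc3ccc(Cl)cc3Cl)nc3ccccc3c2=O)n(Cc2ccccc2)c1=O` differs from compound 3 by phenyl in place of hydrogen on a saturated chain carbon bound to an aromatic nitrogen. Among the compounds with values here, no measured pair isolates this change. Compound 2 carries the same benzyl group but also a different aryl group elsewhere, and its 79% sits near the value of compound 3. Within the data shown here, because the one comparable change, a number 8.8 percentage points higher from compound 1 to compound 3 (within the scatter), stayed within the scatter, the step from compound 3 to compound 4 is expected to be small, a number 3.3 percentage points higher from compound 3 to compound 4 (within the scatter). Compound 4 is therefore estimated at 77% in this assay, within a range from 67% to 87%.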

Compound 4, a percentage reported as inhibition, in the whole organism at one dose (the size of the read-out at that dose, not a potency): 77.2%
Compound 4: middle estimate off by 0.2 percentage points, on the low side, and the stated range covers the measured number.
By their numbers in this assay, from the lowest: compounds 1, 3, 4 and 2 (each within the scatter of the next, the first and the last beyond it).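

In this assay, methyl to benzyl on the aromatic nitrogen gives a number 3.5 percentage points higher from compound 3 to compound 4 (within the scatter) and so leaves no readable difference between these two groups at this position. Benzyl in place of hydrogen on that nitrogen gives a number 12.3 percentage points higher from compound 1 to compound 4 (beyond the scatter) and is the only single change shown here that passes the scatter, though the gain is modest. Chloro in place of hydrogen on an aromatic carbon of the phenyl group gives a number 1.8 percentage points lower from compound 2 to compound 4 (within the scatter) and shows no readable effect of that change on a compound carrying benzyl.

From the compounds shown here alone, it remains open how the nitrogen would respond to a longer chain or to a chain ending in an amine or a carboxylic acid. Nothing available explains any of these steps.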